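Rejoining the Piperidine of Compound 2

This account rests on a few compounds, and the source may have more. Where it says the series, first, only, none or still open, it means among the compounds named here.

In a functional assay on TMD8 cells (Homo sapiens) for cytotoxicity, read by CCK-8 assay, with a stated time of 72 h (a lower number here means a stronger inhibitor, a higher number a weaker inhibitor), compound 1 (`Cn1cc(NC(=O)c2ncn3ccc(N4CCC[C@@H](N)C4)nc23)c(C(F)F)n1`) reaches only a limit (> 50000 nM) and gives no number. Going by the values given here, compound 2 (`Cn1cc(NC(=O)c2cnc3ccc(N4CCC[C@@H](N)C4)nn23)c(C(F)F)n1`) provides the only actual number so far (17800 nM), so no measured step exists to set beside it. Compound 3 (`Cn1cc(NC(=O)c2cnc3ccc(N[C@H]4CCCNC4)nn23)c(C(F)F)n1`) has the same atoms as compound 2, joined differently: (piperidin-3-yl)amino enters in place of 3-aminopiperidin-1-yl on an aromatic carbon of the six-membered aromatic ring with 2 nitrogen ((piperidin-3-yl)amino in place of 3-aminopiperidin-1-yl on an aromatic carbon). Among the compounds with values here, no measured pair shows what this exchange does, so the expectation rests on the structural change alone and carries a wide margin. A moderate move toward stronger inhibition in this assay is expected, and the estimated step is (a 4.5-fold lower number from compound 2 to compound 3 (0.65 log units; beyond the scatter)). For compound 3 the estimated value is (4000 nM), with an expected range from (400 nM) to (30000 nM).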

Compound 3, half-maximal inhibitory concentration: 22300 nM
Estimate against measurement, compound 3: 5.6-fold (0.75 log units) below; low and high end bracket the measured number.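

In this assay, going by these compounds alone, the first comparison with a real number on both sides shows a 1.3-fold higher number from compound 2 to compound 3 (0.10 log units; within the scatter), as 3-aminopiperidin-1-yl gives way to (piperidin-3-yl)amino. At this aromatic carbon, then, the way the piperidine is joined to the core, and the additional hydrogen-bond donor that comes with the new link, make no difference that this assay can separate. Compound 1 remains a limit and offers no step to set beside this one: the limit of > 50000 nM in this assay, at which 1 of the 3 values shown sits.

Open, going by these compounds, is whether a different group at this carbon, such as a morpholine or a 2-aminoethylamino chain, would shift the number beyond the scatter. Also open, on these data alone, are what the opposite stereocentre of the (piperidin-3-yl)amino group would do and whether the same exchange would read alike on the core of compound 1.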